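Isoxazole substituent change on a pyrazolopyrimidine kinase inhibitor

The source may hold more compounds than are shown below. What is called first, only, known or untested is meant among the compounds shown, and "the series" means these compounds.

Compound 2 `CC(C)c1cc(-c2nn(C(C)C)c3ncnc(N)c23)no1` stands lowest of the two numbers measured: in an assay on isolated protein for inhibition of proto-oncogene tyrosine-protein kinase receptor Ret (Homo sapiens), read by radiometric assay and 33P incorporation, in the presence of a further agent that is not named here (a lower number here means a stronger inhibitor, a higher number a weaker inhibitor), compound 2 gives 41 nM, while compound 1 `CC(C)n1nc(-c2cc(C(C)(C)C)on2)c2c(N)ncnc21` gives 210 nM. Within the data shown here, the only measured step, a 5.1-fold lower number from compound 1 to compound 2 (0.71 log units; beyond the scatter), concerns a different position. Compound 3 `CC(C)n1nc(-c2cc(-c3ccc(F)cc3)on2)c2c(N)ncnc21` differs from compound 2 by 4-fluorophenyl in place of isopropyl on an aromatic carbon. Among the measured compounds shown here, no measured step covers this change, so the expected shift a 1.2-fold lower number from compound 2 to compound 3 (0.07 log units; within the scatter) is small and uncertain in direction. Compound 3 is therefore estimated at 35 nM, within a range from 8 nM to 150 nM.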

Compound 3, half-maximal inhibitory concentration: 150 nM
Estimate against measurement, compound 3: 4.3-fold (0.63 log units) below; measured number inside the range.
By their numbers in this assay, from the lowest: compound 2; then compounds 3 and 1 (each within the scatter of the next).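

At this position, next to the ring oxygen, replacing isopropyl with 4-fluorophenyl gives a 3.7-fold higher number from compound 2 to compound 3 (0.56 log units; beyond the scatter), so the aromatic ring does not retain the level of compound 2. Replacing tert-butyl with the same group gives a 1.4-fold lower number from compound 1 to compound 3 (0.15 log units; within the scatter), so compound 1 and compound 3 cannot be told apart and, of the three groups, only isopropyl stands out. No supporting evidence accompanies these numbers to explain this. On these data alone, it remains open whether cyclopropyl or methyl would match isopropyl, and whether unsubstituted phenyl would match 4-fluorophenyl.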